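Swapping a methoxyethyl arm for a diethylurea group

A few compounds are considered here, and "the series" means these few. Any claim that something is new, unique, unknown or untested is made for them only; others in the source may bear on it.

Four close relatives share one core and differ only in the group carried by a nitrogen on an aromatic ring. Compound 1 `CC(C)(C)OC(=O)Nc1ncc(C(Oc2ccc3cc(Br)ccc3c2)c2ccc(Cl)cc2)s1` bears a tert-butyl carbamate there, compound 2 `Clc1ccc(C(Oc2ccc3cc(Br)ccc3c2)c2cnc(NCC3CCCCC3)s2)cc1` a cyclohexylmethylamino group and compound 3 `COCCNc1ncc(C(Oc2ccc3cc(Br)ccc3c2)c2ccc(Cl)cc2)s1` a (2-methoxyethyl)amino group. All three were tested in an ADME assay on HepG2 2.2.15 cells (Homo sapiens) for cytotoxicity; on this read-out higher numbers stand for lower toxicity in this test and lower numbers for higher toxicity in this test. In this assay compound 1 reaches only the limit of the test, > 50000 nM, so no exact number is known for it. In this assay compound 2 is recorded as "not toxic" (no number reported). In this assay compound 3 is likewise recorded as "not toxic" (no number reported), so it stands without a number among compounds that show no measurable harm to the cells; the one numeric entry is the limit of > 50000 nM in this assay, at which 1 of the 3 values shown sits. Within the data shown here, no step between two measured compounds has been worked out, so nothing yet shows how any exchange on that nitrogen shifts the read-out.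

Compound 4 `CCN(CC)C(=O)Nc1ncc(C(Oc2ccc3cc(Br)ccc3c2)c2ccc(Cl)cc2)s1` has not been measured. It differs from compound 3 by diethylcarbamoyl in place of 2-methoxyethyl on a nitrogen on an aromatic ring. Because compound 3 reads "not toxic" (no number reported), the step to compound 4 is expected to stay within the scatter, with no clear direction. Compound 4 is therefore estimated at 60000 nM in this assay, between 20000 nM and 200000 nM, and most likely reported only as a limit again.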

Compound 4, half-maximal cytotoxic concentration: "not toxic" (no number reported)
Compound 4 has no reported number here; no gap can be computed for the estimate.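

In this assay, among these compounds, compound 4 is recorded as "not toxic" with no number, just as compound 3 is, so no step between compound 3 and compound 4 can be read. The compounds shown leave open how far any exchange of the group on that nitrogen shifts the concentration at which cells are harmed.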